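Bromo for isopropoxy on the fused ring of compound 3

The source may hold more compounds than are shown below. What is called first, only, known or untested is meant among the compounds shown, and "the series" means these compounds.

Among the measured compounds shown here, in an assay on isolated protein for displacement of a labelled ligand from 5-hydroxytryptamine receptor 6 (Homo sapiens), read by radioligand binding (on this read-out higher numbers stand for weaker inhibition and lower numbers for stronger inhibition), compound 3 `CC(C)Oc1cc2c(cc1NS(=O)(=O)c1ccc(-c3ccc(Cl)cc3)cc1)CCN(C)CC2` gives 31.6 nM, the second highest of the three numbers measured so far. Its nearest neighbour is compound 1 `CN1CCc2cc(Cl)c(NS(=O)(=O)c3ccc(-c4ccc(Cl)cc4)cc3)cc2CC1`, which gives 50.1 nM, a difference within the scatter. The furthest is compound 2 `CN1CCc2ccc(NS(=O)(=O)c3ccc(-c4ccc(F)c(Cl)c4)cc3)cc2CC1`, which gives 7.94 nM, a gap beyond the scatter. Compound 4 `CN1CCc2cc(Br)c(NS(=O)(=O)c3ccc(-c4ccc(Cl)cc4)cc3)cc2CC1` has not yet been measured. Its change from compound 3: bromo in place of isopropoxy on an aromatic carbon. For the measured compounds named here, one measured step bears on this position: a 1.6-fold lower number from compound 1 to compound 3 (0.20 log units; within the scatter). Going by the values given here, no bromo analogue has been measured on this core, so that step, read in reverse, is the only guide; compound 4 matches compound 1 apart from bromo in place of chloro at the same position. On that basis the expected step is a 1.4-fold higher number from compound 3 to compound 4 (0.15 log units; within the scatter), a movement not expected to exceed the scatter. Compound 4 is therefore estimated at 45 nM, with a range of 15 nM to 130 nM, close to the number of compound 1.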

Compound 4, inhibition constant: 50.1 nM
Beside the measured number, compound 4's estimate is 1.1-fold (0.05 log units) below it; the measured number falls inside the stated range.
By their numbers in this assay, from the lowest: compound 2; then compounds 3, 1 and 4 (each within the scatter of the next).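

In this assay, bromo and chloro on this aromatic carbon, ortho to a large group, cannot be told apart, with no change at the digits printed from compound 1 to compound 4 (within the scatter) for that exchange on the shared core. Bromo and isopropoxy also stay within the scatter of each other, with a 1.6-fold higher number from compound 3 to compound 4 (0.20 log units; within the scatter) for a change from 4 heavy atoms to 1 heavy atom, so among these three groups the count of heavy atoms goes with no step beyond the scatter. Nothing at hand explains this flat response.

From the compounds shown here alone, whether an amine, a carboxylic acid or a longer alkoxy chain at this position would move the number beyond the scatter remains open. Going by these compounds, the effect of hydrogen here, on an otherwise unchanged compound 4, is also open.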